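This account rests on a few compounds, and the source may have more. Where it says the series, first, only, none or still open, it means among the compounds named here.

Measured compounds:
Compound 1, `O=C(NCc1ccccc1)c1ccc(C(=O)C(F)(F)F)s1`: 370 nM
Compound 2, `O=C(c1ccc(-c2nc(-c3cccc(C(F)(F)F)c3)no2)s1)C(F)(F)F`: 2450 nM

In an assay on isolated protein for inhibition of protein deacetylase HDAC6 (Homo sapiens) (a higher number here means a weaker inhibitor, a lower number a stronger inhibitor), compound 1 gives 370 nM, and compound 2 gives 2450 nM. Of the two numbers, that of compound 2 is the higher one; compound 1 sits at a number low enough that the gap between the two lies beyond the scatter of this assay. Compound 2 is therefore the weaker of the two measured compounds.

Compound 3, `Cc1cccc(-c2noc(-c3ccc(C(=O)C(F)(F)F)s3)n2)c1`, keeps the whole of compound 2 except for one change: methyl in place of trifluoromethyl on an aromatic carbon. The group that leaves and the group that enters both sit on the same aromatic carbon of a six-membered aromatic ring of carbon only, meta to a large group. Going by the values given here, no measured pair in this set shows the effect of exactly this exchange, so no measured step can be carried over.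

Among the compounds with values here, with only two values to go by, the expected step from compound 2 to compound 3 is a 1.2-fold lower number from compound 2 to compound 3 (0.09 log units; within the scatter), with no firm direction and no change expected beyond the scatter. Compound 3 is thus estimated at 2000 nM, within an expected range from 700 nM to 6000 nM.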

Compound 3, half-maximal inhibitory concentration: 680 nM
Beside the measured number, compound 3's estimate is 2.9-fold (0.47 log units) above it; the measured number lies below the stated range.
By their numbers in this assay, from the lowest: compounds 1 and 3 (each within the scatter of the next); then compound 2.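

In this assay, putting methyl in place of trifluoromethyl on an aromatic carbon, meta to a large group, gives a step beyond the scatter (a 3.6-fold lower number from compound 2 to compound 3 (0.56 log units; beyond the scatter)). This shows that the group on this carbon of the six-membered aromatic ring of carbon only matters to the read-out, and that for this pair the smaller count of heavy atoms goes with the stronger inhibitor. It is the only single-place exchange among the compounds shown, so the finding rests on one modest step and one pair, and nothing measured here explains why the exchange has this effect.

One pair cannot show whether the number follows the size of the group on this carbon or depends on the fluorine atoms themselves, so a bare hydrogen, a chlorine atom, an ethyl group, a methoxy group or an amine on the same carbon would each be needed to tell these readings apart. Going by these compounds, it also remains open whether methyl would give a step of similar size on another carbon of the same ring, or on a different core.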